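Quinolinone-core tertiary amines: cytotoxicity limits and a trifluoromethoxy swap

The source may report more compounds than this note shows. Statements on the series, on what has been measured and on what is new or still open speak of the compounds shown alone.

Compound 1 `Cc1ccc2[nH]c(=O)c(CN(Cc3ccc(OC(F)(F)F)cc3)Cc3ccc(C(C)(C)C)cc3)cc2c1`: > 5000 nM 
Compound 2 `Cc1ccc2[nH]c(=O)c(CN(Cc3ccc(N(C)C)cc3)Cc3ccc(C(C)(C)C)cc3)cc2c1`: > 5000 nM 
Compound 3 `CC(c1ccc(N(C)C)c(Cl)c1)N(Cc1ccc(C(C)(C)C)cc1)Cc1cc2cc(C3CC3)ccc2[nH]c1=O`: > 10000 nM 

All three were examined in a toxicity assay on MDCK cells (Canis lupus familiaris) for cytotoxicity, read by crystal violet staining, with a stated time of 48 h; on this read-out higher numbers stand for lower toxicity in this test and lower numbers for higher toxicity in this test. For compound 1 the value is a limit of this test, not a number. For compound 2 the value is likewise a limit. For compound 3 the value is also a limit, (the limit of > 10000 nM in this assay, at which 1 of the 3 values shown sits). The change trifluoromethoxy in place of dimethylamino on an aromatic carbon gave a step that the two limits leave unreadable from compound 2 to compound 1, both ends sitting at the limit of > 5000 nM in this assay, at which 2 of the 3 values shown sit. The difference between the core of compound 3 and that of compound 2 is not broken down here.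

Compound 4 `CC(c1ccc(OC(F)(F)F)c(Cl)c1)N(Cc1ccc(C(C)(C)C)cc1)Cc1cc2cc(C3CC3)ccc2[nH]c1=O` carries the same kind of change, (trifluoromethoxy in place of dimethylamino on an aromatic carbon); around the place it differs in being ortho to a chloro group, which the earlier change was not. In this assay compound 4 is expected to give 15000 nM, a step that the limit leaves unreadable from compound 3 to compound 4, resting on compound 3 giving only a limit, > 10000 nM, with no readable size from the earlier step.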

Compound 4, half-maximal cytotoxic concentration: > 10000 nM
Compound 4: a limit, no number; the forecaster's own chance of this, stated with the estimate: 80%; the middle value lies beyond the limit too.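

Compound 3 and compound 4 both stop at a limit in this assay, so no step can be read between them. The compounds shown leave open whether trifluoromethoxy in place of dimethylamino shifts the half-maximal cytotoxic concentration at all.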